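Replacing the thiophene of compound 1 with an oxime ether

The source may hold more compounds than are shown below. What is called first, only, known or untested is meant among the compounds shown, and "the series" means these compounds.

Within the data shown here, compound 1, `c1csc(-c2ccccc2NCC2=NCCN2)c1`, sits lowest of the three numbers measured so far in a functional assay for activation of Alpha-1D adrenergic receptor (Homo sapiens); on this read-out lower numbers stand for an effect already at smaller amounts and higher numbers for an effect only at larger amounts of compound: compound 1 gives 18.2 nM. Compound 2, `c1ccc(-c2ccccc2NCC2=NCCN2)nc1`, in this assay gives 41.7 nM, and compound 3, `c1cnc(-c2ccccc2NCC2=NCCN2)nc1`, gives 81.3 nM. The steps among them are all modest: a 2.3-fold higher number from compound 1 to compound 2 (0.36 log units; beyond the scatter), a 4.5-fold higher number from compound 1 to compound 3 (0.65 log units; beyond the scatter), while a 1.9-fold higher number from compound 2 to compound 3 (0.29 log units; within the scatter).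

Compound 4, `CC/C(=N\OC)c1ccccc1NCC1=NCCN1`, is derived from compound 1 by a single change: a group of 6 heavy atoms (4 carbon, 1 nitrogen, 1 oxygen; no ring) in place of a group of 5 heavy atoms (4 carbon, 1 sulfur; one five-membered aromatic ring with 1 hetero atom), on an aromatic carbon. The two measured steps that bear on it both swap the same five-membered ring for a different six-membered aromatic ring and both move the number upward, by the modest amounts shown for compound 2 and compound 3. The change to compound 4 is larger in kind, since the ring is lost altogether and an open chain with a double bond outside an aromatic ring takes its place, so a step of similar direction but somewhat greater size is expected.

Compound 4 is therefore expected to give about 75 nM in this assay, within a range of 25 nM to 250 nM. Among the measured compounds shown here, that estimate means a 4.1-fold higher number from compound 1 to compound 4 (0.61 log units; beyond the scatter), a step expected to go beyond the scatter, though the direction rests on only two comparisons.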

Compound 4, half-maximal effective concentration: < 100000 nM
Compound 4 ended at the assay's limit (the forecaster's own chance of this, stated with the estimate: 5%); the middle value does not contradict the limit.
By their numbers in this assay, from the lowest: compound 1; then compounds 2 and 3 (each within the scatter of the next).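

In this assay compound 4 gives < 100000 nM as a limit of the assay, not a number. The steps from compound 1, compound 2 and compound 3 to compound 4 therefore cannot be read: the limit of < 100000 nM in this assay, at which 1 of the 4 values shown sits. The compounds shown leave open how far the open chain of compound 4 actually lies from the three aromatic rings it is compared with.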